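Swapping the Ester Group: What Toxicity to Expect

A few compounds are considered here, and "the series" means these few. Any claim that something is new, unique, unknown or untested is made for them only; others in the source may bear on it.

Of the compounds shown here, three sharing one core have been measured in a functional assay on HeLa cells (Homo sapiens) for cytotoxicity; on this read-out higher numbers stand for lower toxicity in this test and lower numbers for higher toxicity in this test. Compound 1 `Nc1ncnc2c1ncn2CC(O)C(=O)OCCO` gives > 400 ug/mL, which is a limit of the assay rather than a number. Compound 2 `CCCCOC(=O)C(O)Cn1cnc2c(N)ncnc21` gives 400 ug/mL. Compound 3 `CC(C)OC(=O)C(O)Cn1cnc2c(N)ncnc21` gives > 400 ug/mL, again a limit of the assay. The new compound 4 `COCCOC(=O)C(O)Cn1cnc2c(N)ncnc21` differs from compound 3 in one place: 2-methoxyethyl in place of isopropyl on an oxygen next to a carbonyl group. Two measured steps change the same oxygen, a step that the two limits leave unreadable from compound 1 to compound 3 and a number no lower from compound 2 to compound 3 (the limit leaves the size open), and neither gives a readable size, while the limit of > 400 ug/mL in this assay, at which 2 of the 3 values shown sit, shows how often only a limit is reported. No step beyond the scatter is therefore expected in this assay. Compound 4 is expected to sit around 400 ug/mL, between 200 ug/mL and 800 ug/mL, an expected step of a number no higher from compound 3 to compound 4 (the limit leaves the size open).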

Compound 4, minimum cytotoxic concentration: > 400 ug/mL
Compound 4 ended at the assay's limit; the forecaster's own chance of this, stated with the estimate: 80%; the middle value sits exactly at the limit.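

In this assay, compound 4 gives > 400 ug/mL, which is a limit of the assay, so placing 2-methoxyethyl on this oxygen brings no measurable toxicity. Within the data shown here, the only step with a direction is a number no lower from compound 2 to compound 4 (the limit leaves the size open); the steps from compound 1 and compound 3 to compound 4 cannot be read. Limits now make up most of the picture at this position: the limit of > 400 ug/mL in this assay, at which 3 of the 4 values shown sit.

From the compounds shown here alone, how far the values of compound 3 and compound 4 lie past that limit remains open. Going by these compounds, whether a longer chain or an amine on this oxygen would bring a readable value also remains open.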